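Methyl-to-methoxy swaps on the aryl ring

The source may report more compounds than this note shows. Statements on the series, on what has been measured and on what is new or still open speak of the compounds shown alone.

Measured compounds:
compound 1, `CCC1=C(O)c2c(oc(-c3ccc(C)cc3C)cc2=O)C(CC)(CC)C1=O`: 41.2 uM
compound 2, `CCC1=C(O)c2c(oc(-c3ccc(OC)cc3C)cc2=O)C(CC)(CC)C1=O`: 20.9 uM
compound 3, `CCC1=C(O)c2c(oc(-c3ccc(OC)c(C)c3)cc2=O)C(CC)(CC)C1=O`: 28.5 uM

In a functional assay on KB cells (Homo sapiens) for antiproliferative activity, read by sulforhodamine B assay, with a stated time of 3 days (on this read-out lower numbers stand for an effect already at smaller amounts and higher numbers for an effect only at larger amounts of compound), the three measured compounds sit close together. The change methoxy in place of methyl on an aromatic carbon gives a 2.0-fold lower number from compound 1 to compound 2 (0.29 log units; within the scatter). Moving the methyl within the ring gives a 1.4-fold higher number from compound 2 to compound 3 (0.13 log units; within the scatter), and a 1.4-fold lower number from compound 1 to compound 3 (0.16 log units; within the scatter). None of the three values can be put in order against the others.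

Compound 4, `CCC1=C(O)c2c(oc(-c3ccc(OC)c(OC)c3)cc2=O)C(CC)(CC)C1=O`, is not yet measured. It differs from compound 3 by methoxy in place of methyl on an aromatic carbon. The cores of compound 1 and compound 3 differ by 4-methoxy-3-methylphenyl in place of 2,4-dimethylphenyl on an aromatic carbon. The surroundings of the swapped group are not the same: in compound 1 the methyl that leaves sits meta to a methyl group and para to a large group, whereas in compound 3 it sits ortho to a methoxy group and meta to a large group, so the step to compound 4 is the same kind of change, not the same change.

For compound 4 the expected step is a 1.4-fold lower number from compound 3 to compound 4 (0.15 log units; within the scatter), resting on the earlier 2.0-fold lower number from compound 1 to compound 2 (0.29 log units; within the scatter), which stayed within the scatter. Compound 4 is expected near 20 uM, between 8 uM and 50 uM.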

Compound 4, concentration for half-maximal effect: 14.7 uM
Estimate against measurement, compound 4: 1.4-fold (0.13 log units) above, within the range that was stated.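

In this assay, methoxy in place of methyl on an aromatic carbon gives a 1.9-fold lower number from compound 3 to compound 4 (0.29 log units; within the scatter). Set beside the earlier case, the change reads alike on the two cores: the same change on two cores in this assay, a 2.0-fold lower number (0.29 log units; within the scatter) from compound 1 to compound 2 and a 1.9-fold lower number (0.29 log units; within the scatter) from compound 3 to compound 4, 1.0-fold (0.01 log units) apart, within the scatter of two such steps. The step thus carries from the core of compound 1 to the core of compound 3 with no difference that can be told apart, but each step alone lies within the scatter, so neither shows a real effect of the change on its own core, and two cases give no rule for other cores in the series.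

The aryl ring in the compounds shown carries only methyl and methoxy, and the ethyl groups on the shared core stay the same throughout. Open, going by these compounds, is how the series reads with a hydroxyl, a chlorine or an amine on the aryl ring, or with a longer chain in place of the ethyl groups, and whether any such group would give a step beyond the scatter.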